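The compounds below may be only part of what the source reports. "The series", "measured", "known", "first", "only" and "open" are said of these compounds alone.

Measured so far:
compound 1, `Cc1ccc(CS(=O)(=O)/C(=C/c2c[nH]c3ccc(Br)cc23)C(=O)c2ccc(Cl)cc2)cc1`: 10000 nM
compound 2, `O=C(/C(=C\c1ccc(F)cc1C(F)(F)F)[S+]([O-])Cc1ccc(Cl)cc1)c1ccc(Cl)cc1`: 50000 nM
compound 3, `Cc1ccc(CS/C(=C/c2sccc2C)C(=O)c2ccc(Cl)cc2)cc1`: 10000 nM

In a functional assay on DU-145 cells (Homo sapiens) for inhibition, read by trypan blue exclusion, with a stated time of 96 h (on this read-out lower numbers stand for stronger inhibition of growth and higher numbers for weaker inhibition of growth), compound 1 gives 10000 nM, the same number at the digits shown as compound 3 at 10000 nM; the two together hold the lowest number of the three, while compound 2 sits apart at 50000 nM, a gap beyond the usual scatter. From compound 1 the step to compound 4, `Cc1ccc(CS(=O)(=O)/C(=C/c2ccc(C)s2)C(=O)c2ccc(Cl)cc2)cc1`, is one change: 5-methylthiophen-2-yl in place of 5-bromo-1H-indol-3-yl on a double-bonded chain carbon bound to a double-bonded chain carbon. Going by the values given here, no measured pair shows this change, so its size is open. Compound 3 already carries a methylthiophene on the same chain carbon and gives a number matching compound 1, which suggests no step beyond the scatter. Compound 4 is therefore estimated at 10000 nM, with a range of 3000 nM to 30000 nM, the expected step being no change at the digits printed from compound 1 to compound 4 (within the scatter).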

Compound 4, concentration for 50% growth inhibition: 25000 nM
Compound 4: the middle estimate sits 2.5-fold (0.40 log units) below what was measured, and the stated range covers the measured number.
By their numbers in this assay, from the lowest: compounds 1 and 3 (each within the scatter of the next); then compounds 4 and 2 (each within the scatter of the next).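

In this assay, putting 5-methylthiophen-2-yl in place of 5-bromo-1H-indol-3-yl on a double-bonded chain carbon bound to a double-bonded chain carbon gives a 2.5-fold higher number from compound 1 to compound 4 (0.40 log units; beyond the scatter). Going by these compounds alone, this is the first one-place comparison in the set, and it shows that this position responds to the group it carries, though only modestly. Nothing measured here explains the step. Going by these compounds, since the whole group changes at once, it stays open which part of 5-bromo-1H-indol-3-yl matters. A plain 1H-indol-3-yl without bromine, or a thiophene carrying an amine, would help separate these parts.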